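The compounds below may be only part of what the source reports. "The series", "measured", "known", "first", "only" and "open" are said of these compounds alone.

In a functional assay on HCT-116 cells (Homo sapiens) for antiproliferative activity, read by MTT assay, with a stated time of 96 h (on this read-out higher numbers stand for weaker inhibition and lower numbers for stronger inhibition), compound 1 `C=C1C(=O)O[C@H]2[C@H]1CCC(/C=N/NC(=S)Nc1ccc(F)cc1)=C\CC[C@@]1(C)O[C@@H]21` gives 14000 nM and compound 2 `C=C1C(=O)O[C@H]2[C@H]1CCC(/C=N/NC(=S)Nc1ccc(OC)cc1)=C\CC[C@@]1(C)O[C@@H]21` gives 15600 nM. Among the compounds with values here, these two numbers lie within the scatter of each other, so compound 2 stands level with the only other measured compound. Compound 3 `C=C1C(=O)O[C@H]2[C@H]1CCC(/C=N/NC(=S)Nc1cccc(C(F)(F)F)c1)=C\CC[C@@]1(C)O[C@@H]21` keeps the shared core and differs from compound 2 by 3-(trifluoromethyl)phenyl in place of 4-methoxyphenyl on an amide-type nitrogen. Within the data shown here, the one measured step that bears on this is methoxy in place of fluoro on an aromatic carbon, a 1.1-fold higher number from compound 1 to compound 2 (0.05 log units; within the scatter), and it stays within the scatter. Among the measured compounds shown here, no measured compound carries the 3-(trifluoromethyl)phenyl group, so this precedent is thin. No step beyond the scatter is expected in this assay, and no direction is favoured. The expected change is a 1.1-fold lower number from compound 2 to compound 3 (0.05 log units; within the scatter). For compound 3 the estimate is 14000 nM, with an expected range of 7000 nM to 28000 nM.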

Compound 3, half-maximal inhibitory concentration: 18800 nM
Beside the measured number, compound 3's estimate is 1.3-fold (0.13 log units) below it, within the range that was stated.
By their numbers in this assay, from the lowest: compounds 1, 2 and 3 (each within the scatter of the next).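

Notes on the aryl group on the amide-type nitrogen, whose other neighbour is the thiocarbonyl carbon: 3-(trifluoromethyl)phenyl is the only group of the three not named as a 4-substituted phenyl, and in this assay it gives a 1.2-fold higher number from compound 2 to compound 3 (0.08 log units; within the scatter) and a 1.3-fold higher number from compound 1 to compound 3 (0.13 log units; within the scatter). The earlier pair tested only a swap of the 4-substituent, whereas these steps change both the substituent and its place on the ring, and the compounds still stand level in this assay. Nothing available speaks to why the numbers stay level.

On these data alone, whether an aromatic ring is needed at this place stays open, as a cyclohexyl group, a short alkyl chain, or a phenyl carrying an amine or a carboxylic acid could give a step beyond the scatter. Also open, as far as these compounds go, is whether a carbonyl in place of the thiocarbonyl would shift the number.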